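Chloro in Place of Fluoro: What Compound 4 Should Give

A few compounds are considered here, and "the series" means these few. Any claim that something is new, unique, unknown or untested is made for them only; others in the source may bear on it.

Of the compounds shown here, three have been measured in a functional assay on A16-F10 cells (Homo sapiens) for antiproliferative activity, read by MTT assay, with a stated time of 48 h; a higher number here means a weaker inhibitor, a lower number a stronger inhibitor. Compound 1 `Fc1ccc(CNc2ccc3ncnc(Nc4cccc(Br)c4)c3c2)cc1` gives 2090 nM, compound 2 `Clc1ccc(CNc2ccc3ncnc(Nc4cccc(Br)c4)c3c2)cc1` gives 1820 nM, and compound 3 `Fc1ccc(CNc2ccc3ncnc(Nc4cccc(Cl)c4)c3c2)cc1` gives 2950 nM in this assay.

Compound 2 arises from compound 1 by chloro in place of fluoro on an aromatic carbon, and that step read a 1.1-fold lower number from compound 1 to compound 2 (0.06 log units; within the scatter). Compound 3 differs from compound 1 in its core by chloro in place of bromo on an aromatic carbon, which read a 1.4-fold higher number from compound 1 to compound 3 (0.15 log units; within the scatter). All three values therefore sit close together, and none of them can be called stronger or weaker than another.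

Compound 4 `Clc1ccc(CNc2ccc3ncnc(Nc4cccc(Cl)c4)c3c2)cc1` has not yet been measured in this assay. It arises from compound 3 through (chloro in place of fluoro on an aromatic carbon), the same change, at the same place, as that from compound 1 to compound 2, made on the core of compound 3 rather than that of compound 1.

The expectation for compound 4 rests on compound 2, whose step from compound 1 was a 1.1-fold lower number from compound 1 to compound 2 (0.06 log units; within the scatter). On that basis compound 4 is expected to show a 1.1-fold lower number from compound 3 to compound 4 (0.05 log units; within the scatter) in this assay. The estimated value of compound 4 in this assay is 2600 nM, expected to fall between 1300 nM and 5200 nM.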

Compound 4, half-maximal inhibitory concentration: 2670 nM
The estimate for compound 4 lay 1.0-fold (0.01 log units) below the measured number; the range from low to high includes it.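

In this assay, chloro in place of fluoro on the aromatic carbon of the 4-fluorobenzyl group gives a 1.1-fold lower number from compound 3 to compound 4 (0.04 log units; within the scatter), and this step matches the earlier one on the other core: the same change on two cores in this assay, a 1.1-fold lower number (0.06 log units; within the scatter) from compound 1 to compound 2 and a 1.1-fold lower number (0.04 log units; within the scatter) from compound 3 to compound 4, 1.0-fold (0.02 log units) apart, within the scatter of two such steps. Chloro in place of bromo gives a 1.5-fold higher number from compound 2 to compound 4 (0.17 log units; within the scatter), and this step likewise matches its earlier counterpart: the same change on two cores in this assay, a 1.4-fold higher number (0.15 log units; within the scatter) from compound 1 to compound 3 and a 1.5-fold higher number (0.17 log units; within the scatter) from compound 2 to compound 4, 1.0-fold (0.02 log units) apart, within the scatter of two such steps. Across these compounds, each change therefore reads the same on both cores, but as every step lies within the scatter, this shows only that neither change shifted the number detectably on either core, not that a small real effect carries over or that a larger step would transfer in the same way.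

The compounds shown carry only fluoro, chloro and bromo at the two varied places, so it remains open how a methoxy group, an amine or a carboxylic acid would read there. From the compounds shown here alone, whether a change with a step beyond the scatter would carry from one core to the other also remains open.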